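Side-chain amine exchange from compound 3 to compound 4

The compounds below may be only part of what the source reports. "The series", "measured", "known", "first", "only" and "open" are said of these compounds alone.

In an ADME assay on microsomes from liver (Mus musculus) for metabolic stability, read by LC-MS, using NADPH, with stated times of 10 min and 30 min, tested at 1 uM (a higher number here means faster removal of the compound, a lower number slower removal), compound 1 (`COC(=O)C1=C(C)NC(c2nccs2)=NC1(C)c1ccc(S(C)(=O)=O)cc1`) gives 57 mL/min/kg and compound 2 (`COC(=O)C1=C(C)NC(c2nccs2)=NC1(C)c1ccc(F)c(F)c1`) gives 83 mL/min/kg with no separation beyond the scatter. Compound 3 (`COC(=O)C1=C(CN2CC3CC2CO3)NC(c2nccs2)=NC1(C)c1ccc(F)cc1`) gives 84 mL/min/kg and lies within the scatter of both. Compound 4 (`COC(=O)C1=C(CN2CCC(F)(F)CC2)NC(c2nccs2)=NC1(C)c1ccc(F)cc1`) differs from compound 3 at one place, where 4,4-difluoropiperidin-1-yl enters (a group of 8 heavy atoms (5 carbon, 1 nitrogen, 2 fluorine; one six-membered non-aromatic ring with 1 hetero atom) in place of a group of 7 heavy atoms (5 carbon, 1 nitrogen, 1 oxygen; 2 five-membered non-aromatic rings with 1 hetero atom each), on a saturated chain carbon bound to a double-bonded ring carbon) on a saturated chain carbon bound to a double-bonded ring carbon. Among the measured compounds shown here, no measured pair differs at one place only, so the expectation rests on compound 3 at 84 mL/min/kg as the starting value. In this assay no step beyond the scatter is expected, in either direction. The estimated change is a 1.1-fold lower number from compound 3 to compound 4 (0.02 log units; within the scatter) and stays within the scatter. The estimated clearance for compound 4 is 80 mL/min/kg in an expected range from 55 mL/min/kg to 110 mL/min/kg.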

Compound 4, clearance: 88 mL/min/kg
Estimate against measurement, compound 4: 1.1-fold (0.04 log units) below; the range from low to high includes it.
By their numbers in this assay, from the lowest: compounds 1, 2, 3 and 4 (each within the scatter of the next).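

On the saturated chain carbon bound to a double-bonded ring carbon, 4,4-difluoropiperidin-1-yl in place of the group with two five-membered non-aromatic rings gives a 1.0-fold higher number from compound 3 to compound 4 (0.02 log units; within the scatter) in this assay. This is the one single-place step shown, and it leaves clearance at this position unseparated within the scatter. Nothing measured here bears on why the two groups cannot be told apart. As far as these compounds go, whether plain piperidin-1-yl, morpholin-4-yl or a chain ending in a carboxylic acid at this position would give a step beyond the scatter remains open.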